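The compounds below may be only part of what the source reports. "The series", "measured", "known", "first", "only" and "open" are said of these compounds alone.

Three compounds with related structures set the scene. In a functional assay on LoVo cells (Homo sapiens) for cytotoxicity, read by colorimetric assay and MTT assay (a higher number here means a weaker inhibitor, a lower number a stronger inhibitor), compound 1 `CCN(CC)C(=O)Cn1c(=O)c(-c2ccc(OC)cc2)cc2c(OC)cc(OC)cc21` gives 10000 nM, compound 2 `COc1cc(OC)c2cc(-c3ccc(O)cc3)c(O)nc2c1` gives 10000 nM and compound 3 `COc1ccc(-c2cc3c(OC)cc(OC)cc3n(C)/c2=N\Nc2ccccc2)cc1` gives 10000 nM. Compound 3 therefore stands level with the other two, and nothing separates the three beyond the usual scatter of repeated measurements. All three are weak inhibitors in this cell test, even though they carry visibly different groups.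

The next structure, compound 4 `COc1ccc(-c2cc3c(OC)cc(OC)cc3n(C)/c2=N\Nc2ccccn2)cc1`, changes compound 3 in one place: pyridin-2-yl in place of phenyl on an amine nitrogen. In words, pyridin-2-yl takes the place of phenyl on an amine nitrogen. The two groups are the same size in heavy atoms, and the difference lies in the ring itself.

Within the data shown here, no measured pair shows this swap, so the data give no direct guide to the size of the step, and any forecast is a judgement. Compound 3 at 10000 nM leaves room for a stronger result, while an unchanged reading would match all three measured compounds. The expected change is a modest gain in strength, a 2.5-fold lower number from compound 3 to compound 4 (0.40 log units; beyond the scatter), with a real chance of no change beyond the scatter. The estimated value for compound 4 is 4000 nM, with an expected range from 800 nM to 10000 nM.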

Compound 4, half-maximal inhibitory concentration: 10000 nM
Beside the measured number, compound 4's estimate is 2.5-fold (0.40 log units) below it; measured number inside the range.
By their numbers in this assay, from the lowest: compounds 1, 2, 3 and 4 (each within the scatter of the next).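

Among these compounds, putting pyridin-2-yl in place of phenyl on an amine nitrogen gives, in this assay, no change at the digits printed from compound 3 to compound 4 (within the scatter) and is the first single-place change that can be read in this set. It shows that this position tolerates a ring nitrogen, with the hydrogen-bond acceptor counted for pyridin-2-yl and the same number of heavy atoms, without any shift in the reading. Nothing available accounts for this unchanged result.

The other pairs differ in more than one place, so their steps cannot be read. Still open, going by these compounds, is whether something other than these two six-membered aromatic rings in place of phenyl on an amine nitrogen, such as a longer chain or a ring carrying a carboxylic acid, would move the reading of compound 3 away from its 10000 nM value.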